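The source may report more compounds than this note shows. Statements on the series, on what has been measured and on what is new or still open speak of the compounds shown alone.

Measured compounds:
- compound 1 `N=c1c(=O)[nH]nc2n1CCN2c1cccc(Cl)c1`: 3%
- compound 2 `COc1ccc(N2CCN/C2=N\N)cc1`: 17%

These two compounds were tested in a functional assay on T47D cells (Homo sapiens) for cytotoxicity, with a stated time of 72 h, tested at 10 ug/mL; a lower number here means a weaker effect, a higher number a stronger effect of the compound at the concentration tested. Compound 1 gives the lowest of the two numbers; compound 2 sits higher, a gap beyond the usual scatter of this kind of measurement. The two share no simple one-step relation, so only their two values can be compared.

The next compound, compound 3 `N=c1c(=O)[nH]nc2n1CCN2c1ccccc1`, differs from compound 1 in a single place, (hydrogen in place of chloro on an aromatic carbon), on an aromatic carbon of a six-membered aromatic ring of carbon only, meta to a large group. For the measured compounds named here, no measured pair shows what this change does. Since compound 1 already gives 3%, a low value, the step is expected to be small and not beyond the scatter, in either direction. The estimated step from a number 1 percentage points higher from compound 1 to compound 3 (within the scatter) reflects this. Compound 3 is therefore expected to give about 4% in this assay, within a range from 0% to 15%.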

Compound 3, a percentage reported as inhibition, at one concentration (the size of the read-out at that concentration, not a potency): 0%
For compound 3 the middle estimate is 4 percentage points above the measured one, within the range that was stated.
By their numbers in this assay, from the lowest: compounds 3 and 1 (each within the scatter of the next); then compound 2.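

In this assay, for the compounds shown here, the swap of chloro for hydrogen on this aromatic carbon, meta to a large group, gives a number 3 percentage points lower from compound 1 to compound 3 (within the scatter) and so provides the first measured reading of this change. At this low level of effect, the chloro makes no difference that can be told from the scatter, so this pair offers no sign that the group contributes to the read-out on the core of compound 1. No available measurement offers an explanation for this result.

With both numbers this low, the pair cannot show whether the same swap would matter in a compound with a stronger effect. Going by these compounds, it also remains open whether an amine or a carboxylic acid on this aromatic carbon would change the read-out beyond the scatter.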